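Swapping a nitro for bromine on the benzyl arm

The source may hold more compounds than are shown below. What is called first, only, known or untested is meant among the compounds shown, and "the series" means these compounds.

Of the compounds shown here, three sharing one core have been tested in a functional assay on BGC-823 cells (Homo sapiens) for antiproliferative activity, read by MTT assay, with a stated time of 24 h; on this read-out higher numbers stand for weaker inhibition and lower numbers for stronger inhibition. Going by the values given here, compound 1 `O=[N+]([O-])c1ccc(CSc2nnc(-c3ccc4c(c3)OCCO4)n2-c2ccccc2)cc1` gives 48600 nM, and it holds the only actual number in the set. The other two values are not numbers but bounds of the assay. Compound 2 `Fc1ccc(CSc2nnc(-c3ccc4c(c3)OCCO4)n2-c2ccccc2)cc1` reaches only the limit of this assay, > 100000 nM. Compound 3 `Fc1ccc(CSc2nnc(-c3ccc4c(c3)OCCO4)n2-c2ccccc2)c(F)c1` likewise sits at the limit, > 100000 nM. The step of an at least 2.0-fold higher number from compound 1 to compound 2 (0.31 log units; beyond the scatter) and the step of an at least 2.0-fold higher number from compound 1 to compound 3 (0.31 log units; beyond the scatter) both point the same way: replacing the nitro-bearing ring with a fluorine-bearing one made inhibition weaker. The step that the two limits leave unreadable from compound 2 to compound 3 cannot be sized, as both ends are limits.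

Compound 4 `Brc1cccc(CSc2nnc(-c3ccc4c(c3)OCCO4)n2-c2ccccc2)c1` is not yet measured. It differs from compound 1 in one place: 3-bromophenyl in place of 4-nitrophenyl on a saturated chain carbon bound to a sulfur. Both measured steps away from compound 1 bear on this change, since each also removed the nitro group in favour of a halogen, and each lost at least a modest amount of activity. The same direction is therefore expected here, and the step of a 1.9-fold higher number from compound 1 to compound 4 (0.27 log units; within the scatter) is estimated to be a loss. Given (the limit of > 100000 nM in this assay, at which 2 of the 3 values shown sit), compound 4 may well land at the limit again. Compound 4 is expected to give about 90000 nM, within a range from 40000 nM to 200000 nM.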

Compound 4, half-maximal inhibitory concentration: 65600 nM
For compound 4 the middle estimate is 1.4-fold (0.14 log units) above the measured one; the measured number falls inside the stated range.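

On the saturated chain carbon bound to a sulfur, the nitro group proves dispensable for a measurable number in this assay: the change to 3-bromophenyl gives a 1.3-fold higher number from compound 1 to compound 4 (0.13 log units; within the scatter), so the two arms cannot be told apart here. Against the fluorinated arms the picture is less firm, with an at least 1.5-fold lower number from compound 3 to compound 4 (0.18 log units; that floor lies within the scatter) and an at least 1.5-fold lower number from compound 2 to compound 4 (0.18 log units; that floor lies within the scatter), so neither comparison establishes a real gain for the 3-bromophenyl arm. The earlier link between losing the nitro group and reaching a limit of the assay therefore does not hold for every halogen: compound 2 and compound 3 fit it, whereas compound 4 goes against it.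

The compounds shown leave open how a 4-bromophenyl arm, which would keep the number in the name of the 4-nitrophenyl arm, or a 4-aminophenyl arm, which would carry an amine, would read on this same carbon. The step between compound 2 and compound 3 also still cannot be read, as neither compound gives an actual number: the limit of > 100000 nM in this assay, at which 2 of the 4 values shown sit.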